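Shortening the Chain-End Amine on a Shared Core

This account rests on a few compounds, and the source may have more. Where it says the series, first, only, none or still open, it means among the compounds named here.

Of the compounds shown here, three sharing one core have been measured in a toxicity assay on L02 cells (Homo sapiens) for cytotoxicity, read by MTT assay, with a stated time of 72 h; a lower number here means a stronger inhibitor, a higher number a weaker inhibitor. Compound 1 `CN1CCN(CCCCCn2c3c(c4ccccc42)C(=O)c2c[n+]([O-])c4ccccc4c2C3=O)CC1` gives 1640 nM. Compound 2 `O=C1c2c[n+]([O-])c3ccccc3c2C(=O)c2c1c1ccccc1n2Cc1cn(C[C@@H](O)CO)nn1` gives 490 nM. Compound 3 `O=C1c2c[n+]([O-])c3ccccc3c2C(=O)c2c1c1ccccc1n2CCCCN1CCCCC1` gives 610 nM, which is the second highest of the three numbers; its gap to compound 2 is within the scatter, while a 2.7-fold lower number from compound 1 to compound 3 (0.43 log units; beyond the scatter) lies beyond it, as does a 3.3-fold lower number from compound 1 to compound 2 (0.52 log units; beyond the scatter).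

Compound 4 `CN(C)CCCCn1c2c(c3ccccc31)C(=O)c1c[n+]([O-])c3ccccc3c1C2=O` is not yet measured. It differs from compound 3 as follows: dimethylamino in place of piperidin-1-yl on a saturated chain carbon, four bonds along the chain from an aromatic nitrogen. Among the measured compounds shown here, the only measured step touching the amine at this position is a 2.7-fold lower number from compound 1 to compound 3 (0.43 log units; beyond the scatter), a modest change that accompanied a larger rearrangement of the chain end than the one here. For the measured compounds named here, no measured pair exchanges a cyclic amine for an acyclic one, so the data offer no direct guide.

The writer therefore expects compound 4 to sit close to compound 3, with a 1.1-fold higher number from compound 3 to compound 4 (0.06 log units; within the scatter) not beyond the scatter. Compound 4 is estimated at 700 nM, within a range from 350 nM to 1400 nM.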

Compound 4, half-maximal inhibitory concentration: 300 nM
For compound 4 the middle estimate is 2.3-fold (0.37 log units) above the measured one; measured number below the stated range.
By their numbers in this assay, from the lowest: compounds 4, 2 and 3 (each within the scatter of the next, the first and the last beyond it); then compound 1.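

In this assay, among the compounds shown here, the first direct exchange of a cyclic amine for an acyclic one at this place, on a saturated chain carbon four bonds along the chain from an aromatic nitrogen, gives a 2.0-fold lower number from compound 3 to compound 4 (0.31 log units; beyond the scatter), so replacing piperidin-1-yl with the smaller dimethylamino does register in this read-out. The same chain end widens the span at the top of the series, with a 5.5-fold lower number from compound 1 to compound 4 (0.74 log units; beyond the scatter), while a 1.6-fold lower number from compound 2 to compound 4 (0.21 log units; within the scatter) leaves those two unseparated. Nothing given here bears on why the number moves with this change.

Going by these compounds, whether the ring itself or the count of heavy atoms matters remains open, and a pyrrolidine, a morpholine or a diethylamino group at this chain end would help to separate the two. How dimethylamino behaves on a shorter or a longer chain also stays unknown from the compounds shown.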